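Removing an acetyl from the second sugar of compound 2

The compounds below may be only part of what the source reports. "The series", "measured", "known", "first", "only" and "open" are said of these compounds alone.

Compound 1 `CCCCCCCCO[C@@H]1O[C@@H](C)[C@H](OC(=O)CCCCC)[C@@H](O[C@@H]2O[C@@H](C)[C@H](OC(C)=O)[C@@H](O)[C@H]2OC(C)=O)[C@H]1O` and compound 2 `CCCCCCCCO[C@@H]1O[C@@H](C)[C@H](OC(=O)CCCCC)[C@@H](O[C@@H]2O[C@@H](C)[C@H](OC(C)=O)[C@@H](OC(C)=O)[C@H]2OC(C)=O)[C@H]1O` share one core and differ by an acetyl in place of hydrogen on an oxygen on a saturated carbon. In a functional assay on KB cells (Homo sapiens) for cytotoxicity (a lower number here means that less compound is needed, a higher number that more compound is needed for the effect), compound 1 reaches only the limit of the assay, > 20 ug/mL. In this assay, for the measured compounds named here, compound 2 gives 12.7 ug/mL, the single numeric value in the set, and the step of an at least 1.5-fold lower number from compound 1 to compound 2 (0.19 log units; that floor lies within the scatter) has its floor within the scatter because the limit of > 20 ug/mL in this assay, at which 1 of the 2 values shown sits, is all that compound 1 shows. Compound 3 `CCCCCCCCO[C@@H]1O[C@@H](C)[C@H](OC(=O)CCCCC)[C@@H](O[C@@H]2O[C@@H](C)[C@H](O)[C@@H](OC(C)=O)[C@H]2OC(C)=O)[C@H]1O` is not yet measured; it differs from compound 2 by hydrogen in place of acetyl on an oxygen on a saturated carbon. Going by the values given here, this is the same kind of change as the measured step, run the other way and at a different oxygen, so a somewhat higher number for compound 3 than for compound 2 would not surprise, though the only measured step gives no firm size. The estimate for compound 3 in this assay is therefore 18 ug/mL, with a range from 9 ug/mL to 40 ug/mL. The expected step of a 1.4-fold higher number from compound 2 to compound 3 (0.15 log units; within the scatter) is modest, and a limit report for compound 3 is quite possible.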

Compound 3, concentration for half-maximal effect: 11.3 ug/mL
Compound 3: middle estimate off by 1.6-fold (0.20 log units), on the high side; the measured number falls inside the stated range.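

For the compounds shown here, on this oxygen, the acetoxy to hydroxy change is the first that can be read with a number at both ends. In this assay, the step is small, a 1.1-fold lower number from compound 2 to compound 3 (0.05 log units; within the scatter), so the two compounds cannot be told apart on this read-out. At this oxygen on a saturated carbon, then, the acetyl can give way to hydrogen without a change that stands clear of the usual scatter, and the cytotoxicity seen for compound 2 does not depend on that acetyl in any way these numbers can show.

Compound 1 is reported only as a limit, which is not a number, so the size of the acetyl step at its free oxygen cannot be read, and neither can a comparison between that oxygen and this one: the limit of > 20 ug/mL in this assay, at which 1 of the 3 values shown sits. The compounds shown also leave open whether any other group on this oxygen, such as a benzoyl ester or an amine in place of the oxygen substituent, would move the number beyond the scatter, and what removing both acetyls together would do.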